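Hydroxyphenyl placement on a pyridyl-bearing shared core

A few compounds are considered here, and "the series" means these few. Any claim that something is new, unique, unknown or untested is made for them only; others in the source may bear on it.

Measured compounds:
compound 1, `Oc1cccc(-c2cc(-c3ccco3)cc(-c3cccc(O)c3)n2)c1`, giving 1890 nM in a functional assay on HCT-15 cells (Homo sapiens) for cytotoxicity, read by CCK-8 assay; a lower number here means a stronger inhibitor, a higher number a weaker inhibitor
compound 2, `Oc1cccc(-c2cc(-c3ccccn3)cc(-c3ccccc3O)n2)c1`, giving > 50000 nM in this assay

Compound 2 reports only a limit in this assay, with no number. Compound 2 thus stands at the limit of > 50000 nM in this assay, at which 1 of the 2 values shown sits. Compound 3, `Oc1cccc(-c2cc(-c3ccccn3)cc(-c3cccc(O)c3)n2)c1`, is not yet measured; it differs from compound 2 by 3-hydroxyphenyl in place of 2-hydroxyphenyl on an aromatic carbon, so that compound 3 carries two 3-hydroxyphenyl groups as compound 1 does. Among the compounds with values here, no measured step of this kind is available, so the size rests on compound 1 alone; the change is expected to move toward stronger inhibition, an estimated at least 8.3-fold lower number from compound 2 to compound 3 (0.92 log units; beyond the scatter). Compound 3 is expected at 6000 nM, within 1500 nM to 50000 nM.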

Compound 3, half-maximal inhibitory concentration: 3510 nM
Estimate against measurement, compound 3: 1.7-fold (0.23 log units) above, within the range that was stated.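

In this assay compound 2 gives only a limit, not a number: the limit of > 50000 nM in this assay, at which 1 of the 3 values shown sits.

Against that limit, 3-hydroxyphenyl in place of 2-hydroxyphenyl on the aromatic carbon next to the ring nitrogen gives an at least 14-fold lower number from compound 2 to compound 3 (1.15 log units; beyond the scatter), so this position distinguishes the two hydroxyphenyl isomers when pyridin-2-yl is present. Pyridin-2-yl in place of furan-2-yl gives a 1.9-fold higher number from compound 1 to compound 3 (0.27 log units; within the scatter), so with two 3-hydroxyphenyl groups in place, this assay does not separate those two rings.

Open, from the compounds shown here alone, is how 4-hydroxyphenyl at this position would compare. Also open, going by these compounds, is whether methoxy or an amine could replace the hydroxyl of the 3-hydroxyphenyl group.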